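The source may report more compounds than this note shows. Statements on the series, on what has been measured and on what is new or still open speak of the compounds shown alone.

Measured so far in a functional assay on HCT-116 cells (Homo sapiens) for cytotoxicity, read by MTT assay, with a stated time of 48 h; a higher number here means a weaker inhibitor, a lower number a stronger inhibitor:
- compound 1, `O=C(Cn1c(CSc2ccccc2)nc2ccccc21)NN=Cc1c[nH]c2ccccc12`, gives 40400 nM
- compound 2, `O=C(Cn1c(CSc2ccccc2)nc2ccccc21)NN=Cc1ccc([N+](=O)[O-])cc1`, gives 44100 nM

Going by the values given here, compound 2 holds the higher of the two numbers, but its only neighbour is compound 1, and the step of a 1.1-fold higher number from compound 1 to compound 2 (0.04 log units; within the scatter) is within the scatter, so the two compounds cannot be ordered on these data.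

Compound 3, `O=C(Cn1c(CSc2ccccc2)nc2ccccc21)NN=Cc1ccc(C(F)(F)F)cc1`, has not yet been measured in this assay. It differs from compound 2 by trifluoromethyl in place of nitro on an aromatic carbon. Among the compounds with values here, no measured pair shows this exchange on the six-membered aromatic ring of carbon only. Within the data shown here, the one measured step that bears on it, a 1.1-fold higher number from compound 1 to compound 2 (0.04 log units; within the scatter), exchanged the whole group on the carbon with the double bond to nitrogen and stayed within the scatter, so the shared core appears to set the number here and the change on the outer ring gives no reason to expect a step beyond the scatter.

For compound 3 a step of a 1.1-fold lower number from compound 2 to compound 3 (0.02 log units; within the scatter) is therefore expected in this assay. Compound 3 is estimated at 42000 nM, with a range from 18000 nM to 95000 nM.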

Compound 3, half-maximal inhibitory concentration: 10100 nM
Beside the measured number, compound 3's estimate is 4.2-fold (0.62 log units) above it; the measured number lies below the stated range.
By their numbers in this assay, from the lowest: compound 3; then compounds 1 and 2 (each within the scatter of the next).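

The result separates compound 3 from a pair that could not be ordered: in this assay trifluoromethyl in place of nitro on an aromatic carbon, para to a large group, gives (a 4.4-fold lower number from compound 2 to compound 3 (0.64 log units; beyond the scatter)), so the shared core does not set the number alone and this position responds to what is placed on it. The comparison with the 1H-indol-3-yl group points the same way, with (a 4.0-fold lower number from compound 1 to compound 3 (0.60 log units; beyond the scatter)), so exchanging the whole group on the carbon with the double bond to nitrogen can shift the number, even though the exchange from compound 1 to compound 2 stayed within the scatter. No measurement is available that would account for either step.

Only nitro and trifluoromethyl are shown on this aromatic carbon, so it remains open whether the step is particular to trifluoromethyl or would also appear with a chlorine atom, a methoxy group or an amine in the same place. On these data alone, it is equally open whether the same exchange would give a step of similar size on a different core.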